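Chain extension at the ring carbon of the sulfonamide series

The source may report more compounds than this note shows. Statements on the series, on what has been measured and on what is new or still open speak of the compounds shown alone.

Measured compounds and values in a functional assay on A2780 cells (Homo sapiens) for antiproliferative activity, read by sulforhodamine B assay, with a stated time of 48 h; on this read-out higher numbers stand for weaker inhibition of growth and lower numbers for stronger inhibition of growth:
- compound 1 `Cc1ccc(S(=O)(=O)N2CCC(Cl)CC2)cc1`: > 100000 nM, a limit of the assay
- compound 2 `Cc1ccc(S(=O)(=O)N2CC=C(Cl)CC2)cc1`: > 100000 nM, a limit of the assay
- compound 3 `Cc1ccc(S(=O)(=O)N2CCC(Cl)=CC2CC(C)C)cc1`: 35000 nM

Going by the values given here, compound 3 is the only member with a number in this assay. The other two values sit at the limit of > 100000 nM in this assay, at which 2 of the 3 values shown sit. Among the compounds with values here, the one step with a number is an at least 2.8-fold lower number from compound 2 to compound 3 (0.45 log units; beyond the scatter); it is a lower bound, since compound 2 gave only a limit.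

Compound 4 `CCCCCCCC1C=C(Cl)CCN1S(=O)(=O)c1ccc(C)cc1` is not yet measured. It differs from compound 3 by hexyl in place of isopropyl on a saturated chain carbon bound to a saturated ring carbon. Within the data shown here, no measured step changes the length of this chain; the step from compound 2 to compound 3 shows only that putting a branched chain on that ring carbon moved the number below the limit. Whether a longer, unbranched chain moves it further is not told by the measured pairs. The expectation is therefore a step of a 1.8-fold lower number from compound 3 to compound 4 (0.24 log units; within the scatter) in this assay, with wide uncertainty and a real chance that compound 4 reports only a limit. For compound 4 the estimate in this assay is 20000 nM, in the range 5000 nM to 100000 nM.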

Compound 4, concentration for 50% growth inhibition: 92000 nM
Compound 4: middle estimate off by 4.6-fold (0.66 log units), on the low side; the measured number falls inside the stated range.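

In this assay, a longer chain at this ring carbon does not bring stronger inhibition of growth: hexyl in place of isopropyl on a saturated chain carbon bound to a saturated ring carbon gives a 2.6-fold higher number from compound 3 to compound 4 (0.42 log units; beyond the scatter). Measured against hydrogen at the same carbon, heptyl gives an at least 1.0-fold lower number from compound 2 to compound 4 (0.03 log units; that floor lies within the scatter), and this floor rests on a limit of the assay, so heptyl is not separated from hydrogen, whereas isobutyl was, with an at least 2.8-fold lower number from compound 2 to compound 3 (0.45 log units; beyond the scatter). The earlier compounds showed only that a chain at this carbon could bring the number under the ceiling of the assay, and the new value shows that this depends on which chain is present and that an unbranched heptyl chain sits close to that ceiling: the limit of > 100000 nM in this assay, at which 2 of the 4 values shown sit.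

This change alters both length and branching, so the two chains cannot say which of these matters; a shorter unbranched chain such as propyl, or a branched chain as long as heptyl, would separate them. On these data alone, it also stays open whether a group other than a plain carbon chain, such as an amine or a carboxylic acid, would improve on compound 3 at 35000 nM.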